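Chain extension in a carbamate-amide series

A few compounds are considered here, and "the series" means these few. Any claim that something is new, unique, unknown or untested is made for them only; others in the source may bear on it.

Compound 1 `CCCCCNC(=O)Oc1ccc(Cl)cc1C(=O)Nc1cccc(Cl)c1` and compound 2 `CCCCCCNC(=O)Oc1ccc(Cl)cc1C(=O)Nc1cccc(Cl)c1` share one core; compound 3 `CCCCCCCCNC(=O)Oc1ccc(Cl)cc1C(=O)Nc1ccc(Cl)cc1` and the unmeasured compound 4 `CCCCCCCCCNC(=O)Oc1ccc(Cl)cc1C(=O)Nc1ccc(Cl)cc1` share another. The difference between the two cores is not broken down here. In a physicochemical assay for lipophilicity (on this read-out lower numbers stand for lower lipophilicity and higher numbers for higher lipophilicity), compound 1 gives 5.11 and compound 2 gives 5.53; the step is a number 0.42 log units higher from compound 1 to compound 2 (beyond the scatter), the change being (methyl in place of hydrogen on a saturated chain carbon, five bonds along the chain from an amide-type nitrogen). Compound 3 gives 6.36 in this assay, the highest of the three numbers, with the gap to compound 2 and the gap to compound 1 both beyond the scatter.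

The change from compound 3 to compound 4 is methyl in place of hydrogen on a saturated chain carbon, eight bonds along the chain from an amide-type nitrogen. It is the same kind of change as that from compound 1 to compound 2, but the place differs: five bonds along the chain from an amide-type nitrogen in the first pair, eight bonds along the chain from an amide-type nitrogen in the second. Across the compounds shown this change occurs twice in all, once measured.

For compound 4 the step expected in this assay is a number 0.44 log units higher from compound 3 to compound 4 (beyond the scatter), set beside the measured step because a number 0.42 log units higher from compound 1 to compound 2 (beyond the scatter) is the only gauge of this kind of change here. Compound 4 is thus estimated at 6.8 in this assay, with a range from 6.45 to 7.15; a single measured pair gives little grounding, so the range is kept wide.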

Compound 4, partition coefficient: 6.78
Compound 4: the middle estimate sits 0.02 log units above what was measured, and the stated range covers the measured number.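

In this assay the new step is a number 0.42 log units higher from compound 3 to compound 4 (beyond the scatter), and it matches in size a number 0.42 log units higher from compound 1 to compound 2 (beyond the scatter), so methyl in place of hydrogen gives the same measured step on both cores, at five bonds along the chain from an amide-type nitrogen in the first pair and at eight bonds in the second. This rests on two pairs only, one per core, and core and place change together, so the agreement cannot be assigned to either; it shows that the step carried over in this one case, not that it is independent of core or place, and it does not extend to other cores or to any other read-out. Nothing offered here accounts for the match in the two steps.

Still open, going by these compounds, is whether the same step would appear on a longer chain, such as a decyl chain, or on a chain ending in an amine or a carboxylic acid. Also open is how the two cores compare when they carry one and the same chain, since no pair shown differs in the core alone.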